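A few compounds are considered here, and "the series" means these few. Any claim that something is new, unique, unknown or untested is made for them only; others in the source may bear on it.

Measured compounds in an ADME assay on HEK293-A cells (Homo sapiens) for cytotoxicity, read by MTT assay, with a stated time of 48 h; a higher number here means a weaker inhibitor, a lower number a stronger inhibitor:
compound 1, `O=C1O[C@@H](CN2CCC(c3ccc(F)cc3)CC2)CN1c1ccc(-n2cc(-c3ccccn3)cn2)c(F)c1`: compound 1 gives > 400 ug/mL, a limit of the assay rather than a number.
compound 2, `O=C1O[C@@H](Cn2ccnc2)CN1c1ccc(-n2cc(-c3ccccn3)cn2)c(F)c1`: compound 2 gives > 400 ug/mL, also a limit rather than a number.

Compound 2 thus stands at the limit of > 400 ug/mL in this assay, at which 2 of the 2 values shown sit, and no order between compound 1 and compound 2 can be read from this. Compound 3, `CNC(=O)[C@H]1CN(c2ccc(-n3cc(-c4ccccn4)cn3)c(F)c2)C(=O)O1`, differs from compound 2 by methylcarbamoyl in place of (1H-imidazol-1-yl)methyl on a saturated ring carbon. Among the compounds with values here, no measured step is available to lean on, so no change beyond the usual scatter is expected in this assay, and the step of a number no higher from compound 2 to compound 3 (the limit leaves the size open) is estimated to be flat. Compound 3 is therefore expected to give about 400 ug/mL, between 200 ug/mL and 800 ug/mL, most likely again reported only as a limit.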

Compound 3, half-maximal inhibitory concentration: 342 ug/mL
Estimate against measurement, compound 3: 1.2-fold (0.07 log units) above; measured number inside the range.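

Compound 3 is the only compound shown that gives a number rather than a limit in this assay, so a group at this position can bring the reading inside the measurable range. Methylcarbamoyl in place of (1H-imidazol-1-yl)methyl gives an at least 1.1-fold lower number from compound 2 to compound 3 (0.06 log units; that floor lies within the scatter), which shows no change beyond the scatter. The true size of the step stays unknown because compound 2 gives only a limit: the limit of > 400 ug/mL in this assay, at which 2 of the 3 values shown sit.

From the compounds shown here alone, what an amine, a carboxylic acid or a longer chain on this ring carbon would give in this assay remains open. So does whether the amide hydrogen of methylcarbamoyl matters to the reading.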